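Another aryl group on the aromatic nitrogen: compound 4

The source may hold more compounds than are shown below. What is called first, only, known or untested is meant among the compounds shown, and "the series" means these compounds.

Compound 1 `N#CC1=C(N)Oc2c(c3nc4ccccc4nc3c3ccccc23)C12C(=O)N(Cc1cnnn1-c1ccccc1Cl)c1ccccc12` — in an ADME assay on L02 cells (Homo sapiens) for antiproliferative activity, read by MTT assay, with a stated time of 48 h (on this read-out lower numbers stand for stronger inhibition and higher numbers for weaker inhibition), compound 1 gives > 50000 nM, which is a limit of the assay rather than a number.
Compound 2 `N#CC1=C(N)Oc2c(c3nc4ccccc4nc3c3ccccc23)C12C(=O)N(Cc1cnnn1-c1ccc(S(N)(=O)=O)cc1)c1ccccc12` — in this assay compound 2 gives > 50000 nM, again a limit.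
Compound 3 `N#CC1=C(N)Oc2c(N)cc3nc4ccccc4nc3c2C12C(=O)N(Cc1cnnn1-c1ccccc1Br)c1ccccc12` — in this assay compound 3 gives 29200 nM.

Compound 3 is thus the only one of the three with a measured number; the other two results sit at the limit of > 50000 nM in this assay, at which 2 of the 3 values shown sit, so nothing can be said about how compound 3 ranks against them.

Compound 4 `Cc1ccc(Cl)cc1-n1nncc1CN1C(=O)C2(C(C#N)=C(N)Oc3c(N)cc4nc5ccccc5nc4c32)c2ccccc21` differs from compound 3 in a single place: 5-chloro-2-methylphenyl in place of 2-bromophenyl on an aromatic nitrogen. Among the compounds with values here, the only measured step between compounds that differ in one place, a step that the two limits leave unreadable from compound 1 to compound 2, also exchanges the aryl group on that aromatic nitrogen, but both of its ends are limits and its size cannot be read. Within the data shown here, no measured step therefore shows how such an exchange moves this read-out. With no readable precedent, the expectation for the change from compound 3 to compound 4 is a step that stays within the usual scatter, in no particular direction; the expected step is a 1.0-fold higher number from compound 3 to compound 4 (0.01 log units; within the scatter). Compound 4 is accordingly estimated at 30000 nM, with a likely range from 10000 nM to 90000 nM.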

Compound 4, half-maximal inhibitory concentration: > 50000 nM
Compound 4 was reported as a limit (the forecaster's own chance of this, stated with the estimate: 35%); middle value at least 1.6-fold (0.22 log units) from the limit.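

Within the data shown here, exchanging 2-bromophenyl for 5-chloro-2-methylphenyl on the aromatic nitrogen gives the first step at this position that can be read at all, since it has a measured number at one end: in this assay the change is an at least 1.7-fold higher number from compound 3 to compound 4 (0.23 log units; that floor lies within the scatter). That figure is only a floor and it lies within the scatter, so the result does not establish that this exchange weakens inhibition, although it leaves open a larger change and shows that this aryl group brings no measurable gain over 2-bromophenyl. The result also adds a third compound at the same limit, and compounds sitting at a limit cannot be ranked against one another: the limit of > 50000 nM in this assay, at which 3 of the 4 values shown sit.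

From the compounds shown here alone, how far the true value of compound 4 lies from that of compound 3 remains open, as does whether the chlorine, the methyl or both together account for the step. Also open, going by these compounds, is whether a plain unsubstituted phenyl, or a phenyl carrying an amine or a carboxylic acid, on this aromatic nitrogen would give a number rather than a limit in this assay.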